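Thiosemicarbazone series on K562 cells: thiophene for hydroxyphenyl

The compounds below may be only part of what the source reports. "The series", "measured", "known", "first", "only" and "open" are said of these compounds alone.

Measured compounds:
compound 1 `CC1=CC[C@H](C(C)(C)NC(=S)N/N=C/c2ccccc2O)CC1` — > 100000 nM (a limit)
compound 2 `COc1cc(/C=N/NC(=S)NC(C)(C)[C@H]2CC=C(C)CC2)ccc1O` — 85200 nM
compound 3 `CC1=CC[C@H](C(C)(C)NC(=S)N/N=C/c2ccccc2[N+](=O)[O-])CC1` — > 100000 nM (a limit)

In a functional assay on K562 cells (Homo sapiens) for inhibition, read by sulforhodamine B assay, with a stated time of 48 h (on this read-out higher numbers stand for weaker inhibition of growth and lower numbers for stronger inhibition of growth), compound 1 gives only a limit, > 100000 nM, and no number. Compound 3 likewise returns only a limit in this assay. For the measured compounds named here, compound 2 is the one member of the set with a measured number, 85200 nM, which is itself weak. Going by the values given here, the single step between measured compounds, a step that the two limits leave unreadable from compound 1 to compound 3, cannot be sized because the limit of > 100000 nM in this assay, at which 2 of the 3 values shown sit, covers both of its ends. Compound 1 therefore stands at the weak edge of what this assay reports, with no readable step leading away from it.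

The change to compound 4 `CC1=CC[C@H](C(C)(C)NC(=S)N/N=C/c2cccs2)CC1` is thiophen-2-yl in place of 2-hydroxyphenyl on a carbon with a double bond to nitrogen. Among the compounds with values here, no measured step bears on this replacement: the only step in the set is unreadable, and compound 2 differs from compound 1 at more than one place, so its value gives no isolated comparison. What the set does show is that all three measured compounds sit at or close to the limit of this assay.

On that basis compound 4 is expected to be weak as well, with an estimated value of 100000 nM and a range from 40000 nM to 250000 nM. The step of a number no higher from compound 1 to compound 4 (the limit leaves the size open) is expected to be none beyond the scatter, with a substantial chance that compound 4 again returns only a limit.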

Compound 4, concentration for total growth inhibition: > 100000 nM
Compound 4 gave a limit, no number; the forecaster's own chance of this, stated with the estimate: 55%; the middle value lies on the limit itself.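

In this assay compound 4 gives > 100000 nM, a limit and not a number. No step from compound 1 to compound 4 can be read, because both compounds end at the same edge of the read-out: the limit of > 100000 nM in this assay, at which 3 of the 4 values shown sit.

The compounds shown leave open how thiophen-2-yl and 2-hydroxyphenyl compare on the shared core.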